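The source may hold more compounds than are shown below. What is called first, only, known or untested is meant among the compounds shown, and "the series" means these compounds.

Working notes on the series. Within the data shown here, compound 1 `COc1ccc(N(CC(=O)NCCCSc2ccccc2)C(=O)CCSC2=C(C)C(=O)c3ccccc3C2=O)cc1` is the only member with a number in a functional assay on A-431 cells (Homo sapiens) for cytotoxicity, read by MTT assay, with a stated time of 24 h; on this read-out lower numbers stand for stronger inhibition and higher numbers for weaker inhibition: in this assay compound 1 gives 17000 nM. Compound 2 `COc1ccc(N(CC(=O)NCCC[Se]c2ccccc2)C(=O)CNC(=O)OC(C)(C)C)cc1` is reported in this assay only as a limit, >= 100000 nM, and so offers no number; it also differs from compound 1 in more than one place, so no step can be read from the pair, only that (the limit of >= 100000 nM in this assay, at which 1 of the 2 values shown sits). Compound 3 `COc1ccc(N(CC(=O)NCCC[Se]c2ccccc2)C(=O)CCSC2=C(C)C(=O)c3ccccc3C2=O)cc1` carries a group of 7 heavy atoms (6 carbon, 1 selenium; one six-membered aromatic ring of carbon only) in place of a group of 7 heavy atoms (6 carbon, 1 sulfur; one six-membered aromatic ring of carbon only), on a saturated chain carbon, three bonds along the chain from an amide-type nitrogen. Among the measured compounds shown here, no measured step covers this exchange; the expected step from compound 1 to compound 3 in this assay, a 1.1-fold lower number from compound 1 to compound 3 (0.05 log units; within the scatter), is none beyond the usual scatter. Compound 3 is thus estimated at 15000 nM, in the range 6000 nM to 40000 nM.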

Compound 3, half-maximal inhibitory concentration: 17000 nM
For compound 3 the middle estimate is 1.1-fold (0.05 log units) below the measured one; measured number inside the range.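

The series now has a readable step, no change at the digits printed from compound 1 to compound 3 (within the scatter) in this assay when a selenium-bearing group of 7 heavy atoms replaces phenylsulfanyl on a saturated chain carbon, three bonds along the chain from an amide-type nitrogen. At this position, the two groups therefore read alike on this assay, which the earlier pair could not show. Nothing given here bears on why the two read alike. Still open, from the compounds shown here alone, is whether an amine, a carboxylic acid or a longer chain at this position would shift the number. One exchange at one position supports no wider pattern.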